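This account rests on a few compounds, and the source may have more. Where it says the series, first, only, none or still open, it means among the compounds named here.

- compound 1 `CC1(C)[C@H]2CC[C@]1(C)N(Cc1cn(-c3ccccc3C#N)nn1)C(=O)C2`: 140 nM
- compound 2 `CC1(C)[C@H]2CC[C@]1(C)N(Cc1cn(-c3cccc(O)c3)nn1)C(=O)C2`: 410 nM

Going by the values given here, in a functional assay on LoVo cells (Homo sapiens) for inhibition, read by MTT assay, with a stated time of 24 h (a lower number here means a stronger inhibitor, a higher number a weaker inhibitor), compound 2, at 410 nM, holds the higher of the two numbers so far. Compound 3 `CC1(C)[C@H]2CC[C@]1(C)N(Cc1cn(-c3cccc(Br)c3)nn1)C(=O)C2` has not been measured. It keeps the shared core and replaces 3-hydroxyphenyl with 3-bromophenyl, which puts bromo in place of hydroxy on an aromatic carbon, meta to a large group: bromo in place of hydroxy on an aromatic carbon.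

Among the compounds with values here, only one measured step bears on this: a 2.9-fold higher number from compound 1 to compound 2 (0.47 log units; beyond the scatter). It is modest and does not isolate the present swap, since it exchanges a different group for the 3-hydroxyphenyl. Within the data shown here, it shows only that compound 1, which has no hydroxy, gives the lower number at 140 nM. Among the measured compounds shown here, no measured pair tests bromo directly, so the evidence for direction is thin. A modest move towards a lower number in this assay is expected, and no change beyond the scatter remains possible. The expected change is a 1.6-fold lower number from compound 2 to compound 3 (0.20 log units; within the scatter). For compound 3 the estimated value is 260 nM, with an expected range of 90 nM to 700 nM.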

Compound 3, half-maximal inhibitory concentration: 30 nM
The estimate for compound 3 lay 8.7-fold (0.94 log units) above the measured number; measured number outside the range, below it.
By their numbers in this assay, from the lowest: compound 3; then compound 1; then compound 2.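

In this assay, going by these compounds alone, bromo in place of hydroxy on an aromatic carbon gives a 14-fold lower number from compound 2 to compound 3 (1.14 log units; beyond the scatter) and so shows that the group at this place, meta to a large group, can shift the number by far more than the single earlier step suggested. Compared with the 2-cyanophenyl group, 3-bromophenyl gives a 4.7-fold lower number from compound 1 to compound 3 (0.67 log units; beyond the scatter) and leaves compound 3 with the lowest number of the series, its steps to both other compounds being beyond the scatter, although this step changes both the group and its place on the ring and cannot separate the two. Nothing measured here explains the shift, and the compounds shown cannot tell whether it reflects the departure of hydroxy or the arrival of bromo.

The compounds shown leave open whether chloro, iodo, methoxy or an amine at this place would give a number closer to that of bromo or to that of hydroxy. Also open, going by these compounds, is whether bromo would keep its low number in the position held by the nitrile in compound 1.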